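The source may report more compounds than this note shows. Statements on the series, on what has been measured and on what is new or still open speak of the compounds shown alone.

Measured in an ADME assay on Vero cells (Chlorocebus sabaeus) for cytotoxicity, read by MTT assay, with a stated time of 72 h; a lower number here means that less compound is tolerated, a higher number that more compound is tolerated:
- Compound 1 `O=c1nc(N2CCN(CC3CCCCC3)CC2)sc2c([N+](=O)[O-])cc(C(F)(F)F)cc12`: > 125000 nM
- Compound 2 `O=C(C1CCCC1)N1CCN(c2nc(=O)c3cc(C(F)(F)F)cc([N+](=O)[O-])c3s2)CC1`: 120000 nM
- Compound 3 `O=C(c1ccc(F)cc1)N1CCN(c2nc(=O)c3cc(C(F)(F)F)cc([N+](=O)[O-])c3s2)CC1`: > 125000 nM

Compound 3 stands at the limit of > 125000 nM in this assay, at which 2 of the 3 values shown sit. For compound 3 this is a limit and not a number. The same is true of the entry for compound 1. Only compound 2 has a true number.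

Compound 4 `CCCC(=O)N1CCN(c2nc(=O)c3cc(C(F)(F)F)cc([N+](=O)[O-])c3s2)CC1` differs from compound 3 in one place: propyl in place of 4-fluorophenyl on a carbonyl carbon. In words, this is propyl in place of 4-fluorophenyl on a carbonyl carbon, whose other neighbour is an amide-type nitrogen in a ring.

The closest measured change sits at this same carbon. It is an at least 1.0-fold higher number from compound 2 to compound 3 (0.01 log units; that floor lies within the scatter), and it stays within the scatter. The change on the ring nitrogen, an at least 1.0-fold lower number from compound 1 to compound 2 (0.01 log units; that floor lies within the scatter), also stays within the scatter, while a step that the two limits leave unreadable from compound 1 to compound 3 cannot be read at all. None of these steps gives a reason to expect a real shift, although none of them tests a propyl group directly.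

In this assay the expected step is an at least 1.0-fold lower number from compound 3 to compound 4 (0.01 log units; that floor lies within the scatter), with nothing expected beyond the scatter. A limit may well be reported again instead of a number. The estimated value for compound 4 is 120000 nM, with an expected range of 65000 nM to 220000 nM.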

Compound 4, half-maximal cytotoxic concentration: > 125000 nM
Compound 4 was reported as a limit; the forecaster's own chance of this, stated with the estimate: 50%; middle value at least 1.0-fold (0.01 log units) from the limit.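

Like compounds 1 and 3, compound 4 is reported in this assay only as a limit, and a limit is not a number: the limit of > 125000 nM in this assay, at which 3 of the 4 values shown sit. The earlier compounds shown here carried only ring groups on this carbonyl carbon, cyclopentyl in compound 2 and 4-fluorophenyl in compound 3, whereas compound 4 shows that propyl, an open chain with no ring, also gives no sign of a lower tolerated concentration in these cells. Within the data shown here, putting propyl in place of cyclopentyl gives an at least 1.0-fold higher number from compound 2 to compound 4 (0.01 log units; that floor lies within the scatter), so this is the only step that can be read, and its true size may be larger than that floor, while the steps from compound 3 to compound 4 and from compound 1 to compound 4 cannot be read, since both ends of each are limits.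

From the compounds shown here alone, compounds 1, 3 and 4 therefore cannot be put in any order, and how far each lies past the limit remains unknown. Going by these compounds, it also remains open whether a longer chain, an amine or a carboxylic acid on this carbonyl carbon would give a true number in this assay and reveal a real difference at this position.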